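This account rests on a few compounds, and the source may have more. Where it says the series, first, only, none or still open, it means among the compounds named here.

In a functional assay on NIH3T3 cells (Mus musculus) (a higher number here means that more compound is needed for the effect, a lower number that less compound is needed), compound 2 `Cn1cncc1C(OCc1ccc(C#N)cc1-c1ccc(C#N)cc1)c1ccc(C#N)cc1` gives < 0.1 nM as a limit of the assay, not a number. Compound 1 `CCCCCCC#Cc1cc(C#N)ccc1COC(c1ccc(C#N)cc1)c1cncn1C` gives > 0.1 nM as a limit too. Compound 3 `Cn1cncc1C(OCc1ccc(C#N)cc1C#CCCc1ccccc1)c1ccc(C#N)cc1` carries 4-phenylbut-1-yn-1-yl in place of 4-cyanophenyl on an aromatic carbon as its change, 4-phenylbut-1-yn-1-yl in place of 4-cyanophenyl on an aromatic carbon. Within the data shown here, the only measured step bearing on this, a number no higher from compound 1 to compound 2 (the limit leaves the size open) with its size open, gives reason to expect a modest rise on going back to a group with a triple bond. The expected step in this assay is estimated as a number no lower from compound 2 to compound 3 (the limit leaves the size open) in these notes. For compound 3 the estimate is 0.1 nM with 0.03 nM to 0.5 nM as the expected range.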

Compound 3, half-maximal effective concentration: 130 nM
For compound 3 the middle estimate is 1300-fold (3.11 log units) below the measured one; the measured number lies above the stated range.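

In this assay, 4-phenylbut-1-yn-1-yl in place of 4-cyanophenyl on this aromatic carbon gives an at least 1300-fold higher number from compound 2 to compound 3 (3.11 log units; beyond the scatter). Both groups hold one six-membered aromatic ring of carbon only, so the presence of that ring does not settle the number at this position. Compound 2 stands at a limit of the assay, so the size of this step is only a bound: the limit of < 0.1 nM in this assay, at which 1 of the 3 values shown sits.

As far as these compounds go, the step between compound 1 and compound 3 cannot be read, and it stays open whether the nitrile or the chain with its triple bond matters more. A plain phenyl or a 4-aminophenyl on this carbon would help separate the two.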